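A few compounds are considered here, and "the series" means these few. Any claim that something is new, unique, unknown or untested is made for them only; others in the source may bear on it.

Working notes on the series. Three compounds with the shared core have numbers in an assay on CHO cells for antagonist activity at transient receptor potential cation channel subfamily V member 1 (Homo sapiens), read by FLIPR; a higher number here means a weaker inhibitor, a lower number a stronger inhibitor: compound 1 `CC(C(=O)NCc1ccc(C(F)(F)F)nc1-c1ccccc1)c1ccc(NS(C)(=O)=O)c(F)c1` gives 6.4 nM, compound 2 `COc1ccc(-c2nc(C(F)(F)F)ccc2CNC(=O)C(C)c2ccc(NS(C)(=O)=O)c(F)c2)cc1OC` gives 25.6 nM, and compound 3 `CC(C(=O)NCc1ccc(C(F)(F)F)nc1-c1ccsc1)c1ccc(NS(C)(=O)=O)c(F)c1` gives 2 nM. Compound 2 stands highest of the three; the step of a 4.0-fold higher number from compound 1 to compound 2 (0.60 log units; beyond the scatter) and the step of a 13-fold lower number from compound 2 to compound 3 (1.11 log units; beyond the scatter) both run beyond the scatter, so compound 2 is the weakest inhibitor shown.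

Compound 4 `Cc1ccc(CCc2nc(C(F)(F)F)ccc2CNC(=O)C(C)c2ccc(NS(C)(=O)=O)c(F)c2)cc1` is not yet measured in this assay. Relative to compound 2 the change is 2-(4-methylphenyl)ethyl in place of 3,4-dimethoxyphenyl on an aromatic carbon. Among the compounds with values here, the steps that bear on it are those leaving or arriving at the 3,4-dimethoxyphenyl: a 4.0-fold higher number from compound 1 to compound 2 (0.60 log units; beyond the scatter) was modest, and a 13-fold lower number from compound 2 to compound 3 (1.11 log units; beyond the scatter) was large. Each time the 3,4-dimethoxyphenyl is exchanged for a smaller group the number falls. Within the data shown here, the 2-(4-methylphenyl)ethyl group has no measured precedent in this set, so the size is uncertain, but a fall is the expectation. Compound 4 is therefore estimated at 10 nM, within a range of 3 nM to 40 nM, which would mean an expected step of a 2.6-fold lower number from compound 2 to compound 4 (0.41 log units; beyond the scatter).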

Compound 4, inhibition constant: 0.6 nM
Estimate against measurement, compound 4: 17-fold (1.22 log units) above; measured number below the stated range.
By their numbers in this assay, from the lowest: compound 4; then compound 3; then compound 1; then compound 2.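

In this assay the aromatic carbon next to the ring nitrogen accepts a 2-(4-methylphenyl)ethyl group, with a 43-fold lower number from compound 2 to compound 4 (1.63 log units; beyond the scatter) and with an 11-fold lower number from compound 1 to compound 4 (1.03 log units; beyond the scatter) as well as a 3.3-fold lower number from compound 3 to compound 4 (0.52 log units; beyond the scatter) on the same change, so a ring held on a chain ranks ahead of the three rings attached directly. Size alone does not order the series, since fewer heavy atoms enter than leave in the large step from the 3,4-dimethoxyphenyl, and that exchange also removes 2 hydrogen-bond acceptors. No measured evidence accounts for this result.

The compounds shown do not separate the contribution of the ethyl chain from that of the 4-methyl group. A plain 2-phenylethyl, a benzyl or a 3-phenylpropyl group at this position would address that question.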